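A few compounds are considered here, and "the series" means these few. Any claim that something is new, unique, unknown or untested is made for them only; others in the source may bear on it.

Compound 3, whose structure is `CC(=O)OCC1COCCOCCOCCOCCOCCO1`, is one of three esters built on the same crown-ether core. In a functional assay on WiDr cells (Homo sapiens) for inhibition, read by sulforhodamine B assay, with a stated time of 48 h (on this read-out higher numbers stand for weaker inhibition of growth and lower numbers for stronger inhibition of growth), compound 3 reports only a limit, > 100000 nM. The same holds for compound 1, `CC/C=C/CC(=O)OCC1COCCOCCOCCOCCOCCO1`, for which this assay gives > 100000 nM. Compound 2, `O=C(CCCCOc1ccccc1)OCC1COCCOCCOCCOCCOCCO1`, likewise sits at a limit in this assay, > 100000 nM. Because all three sit at the limit of > 100000 nM in this assay, at which 3 of the 3 values shown sit, none of the steps among them can be read: the step that the two limits leave unreadable from compound 1 to compound 2, the step that the two limits leave unreadable from compound 1 to compound 3 and the step that the two limits leave unreadable from compound 2 to compound 3 are all of unreadable size, each swapping one substituent for another on a saturated chain carbon bound to a carbonyl carbon.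

Compound 4, `O=C(CCCc1cc2ccccc2[nH]1)OCC1COCCOCCOCCOCCOCCO1`, extends compound 3 in the same place: 2-(1H-indol-2-yl)ethyl in place of hydrogen on a saturated chain carbon bound to a carbonyl carbon. The measured steps bear on this change only in that every variation of that substituent so far, from a short alkenyl to a phenoxy-bearing chain to hydrogen, has left the value at the limit. No direction can therefore be read for the step to compound 4, and no movement beyond the scatter is expected. Compound 4 is accordingly estimated at 100000 nM in this assay, between 20000 nM and 300000 nM, which corresponds to an expected step of a number no higher from compound 3 to compound 4 (the limit leaves the size open).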

Compound 4, concentration for 50% growth inhibition: > 100000 nM
Compound 4 gave a limit, no number (the forecaster's own chance of this, stated with the estimate: 80%); the middle value lies on the limit itself.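

Compound 4 also reports only a limit, so its steps from compound 1, compound 2 and compound 3 cannot be read, and all four compounds stand at the same point: the limit of > 100000 nM in this assay, at which 4 of the 4 values shown sit. The compounds shown leave open whether any change of the substituent on the saturated chain carbon bound to a carbonyl carbon can move the growth inhibition to a measurable value.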